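The compounds below may be only part of what the source reports. "The series", "measured", "known", "first", "only" and "open" are said of these compounds alone.

Measured compounds:
Compound 1, `CC(C)CSc1nc(N)nc2c1ncn2/C=C1/CC1(CO)CO` — "not determined" (no result reported).
Compound 2, `CCCCCCCCOc1nc(N)nc2c1ncn2/C=C1/CC1(CO)CO` — > 20000 nM.

Compound 1 stands without a number in an ADME assay on MOLT-3 cells (Homo sapiens) for cytotoxicity, with a stated time of 7 days; on this read-out lower numbers stand for higher toxicity in this test and higher numbers for lower toxicity in this test: no result was reported for it. Among the measured compounds shown here, the only value shown in this assay belongs to compound 2, and it is a limit of the assay rather than a measured number, (the limit of > 20000 nM in this assay, at which 1 of the 2 values shown sits). So compound 1 cannot be placed against compound 2 on measured toxicity.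

Compound 3, `Nc1nc(NCc2ccccc2)c2ncn(/C=C3/CC3(CO)CO)c2n1`, has not yet been tested. It differs from compound 1 in one place: benzylamino in place of isobutylsulfanyl on an aromatic carbon. For the measured compounds named here, no measured step between compounds with a known value is available here, so the size of the change in this assay cannot be read from the data; the expectation is a step no larger than the usual scatter, in no particular direction. Compound 3 is therefore expected to give about 20000 nM, with a likely range from 5000 nM to 60000 nM, and a fair chance that only a limit is reported.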

Compound 3, half-maximal cytotoxic concentration: > 20000 nM
Compound 3: no number, only a limit (the forecaster's own chance of this, stated with the estimate: 65%); the middle value sits exactly at the limit.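

Compound 2 and compound 3 each carry only a limit in this assay, so no step between them can be read: the limit of > 20000 nM in this assay, at which 2 of the 3 values shown sit.

Left open is the concentration at which any of these compounds becomes toxic in this assay, and whether octyloxy, isobutylsulfanyl or benzylamino on the aromatic carbon shifts it.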